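The compounds below may be only part of what the source reports. "The series", "measured", "known", "first", "only" and "open" are said of these compounds alone.

Two compounds share the core and differ only at the amino group on the aromatic ring. Compound 1 `CCCCC#Cc1nc(NCc2cccc(I)c2)c2ncn([C@H]3[C@H](O)[C@H](O)[C@@H]4C[C@@H]43)c2n1` carries a 3-iodophenyl on the saturated chain carbon bound to that nitrogen, and in an assay on RBL-2H3 cells for displacement of a labelled ligand from adenosine receptor A3 (Rattus norvegicus), with a stated time of 60 min (on this read-out higher numbers stand for weaker inhibition and lower numbers for stronger inhibition), compound 1 gives 26 nM. Compound 2 `CCCCC#Cc1nc(NCC)c2ncn([C@H]3[C@H](O)[C@H](O)[C@@H]4C[C@@H]43)c2n1` carries a methyl in its place, and in this assay compound 2 gives 176 nM. Among the measured compounds shown here, the step of a 6.8-fold higher number from compound 1 to compound 2 (0.83 log units; beyond the scatter) is the only measured step, and it leaves compound 2 with the higher of the two numbers.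

Compound 3 `CCCCC#Cc1nc(NC2CCCC2)c2ncn([C@H]3[C@H](O)[C@H](O)[C@@H]4C[C@@H]43)c2n1` is not yet measured. Its change from compound 2 is cyclopentyl in place of ethyl on a nitrogen on an aromatic ring. For the measured compounds named here, no measured step bears directly on this change; the one measured step concerns the other end of the series, where the larger group sat on the same nitrogen and gave the lower number. Taking that step as the only guide, a modest move toward a lower number is expected, estimated as a 1.8-fold lower number from compound 2 to compound 3 (0.25 log units; within the scatter). For compound 3 the expected value in this assay is estimated at 100 nM, within a range from 30 nM to 400 nM.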

Compound 3, inhibition constant: 58 nM
For compound 3 the middle estimate is 1.7-fold (0.24 log units) above the measured one; measured number inside the range.
By their numbers in this assay, from the lowest: compound 1; then compound 3; then compound 2.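

In this assay the first pair had linked a lower number on this nitrogen only to a group carrying a 3-iodophenyl, whereas the change from ethyl to cyclopentyl now gives a 3.0-fold lower number from compound 2 to compound 3 (0.48 log units; beyond the scatter) with one five-membered non-aromatic ring of carbon only, so among these compounds an aromatic ring in this group is not needed for a lower number than that of the ethyl. The cyclopentyl does not match the 3-iodobenzyl, however, and replacing the latter with it gives a 2.2-fold higher number from compound 1 to compound 3 (0.35 log units; beyond the scatter), which places compound 3 clearly between the other two compounds rather than level with either. Nothing given here explains either step, and no measurement bears on why these groups rank as they do.

On these data alone, it remains open whether the lower number of compound 3 goes with the ring itself or simply with the larger count of carbons, a question that an open pentyl chain or a cyclohexyl on the same nitrogen would address. As far as these compounds go, it also remains open how much of the lower number of compound 1 belongs to the iodine and how much to the phenyl ring, which a plain benzyl group would separate.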